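Halogen swap on the aryl triazole of compound 1

The source may report more compounds than this note shows. Statements on the series, on what has been measured and on what is new or still open speak of the compounds shown alone.

Among the compounds with values here, compound 1 `CC1(C)[C@H]2CC[C@]1(C)N(Cc1cn(-c3cccc(F)c3)nn1)C(=O)C2` gives 430 nM in a functional assay on OVCAR-3 cells (Homo sapiens) for inhibition, read by MTT assay, with a stated time of 24 h (a higher number here means a weaker inhibitor, a lower number a stronger inhibitor), the highest number among the three measured members; compound 2 `CC1(C)[C@H]2CC[C@]1(C)N(Cc1cn(-c3ccccc3C#N)nn1)C(=O)C2` gives 110 nM and compound 3 `CC1(C)[C@H]2CC[C@]1(C)N(Cc1cn(-c3ccccc3O)nn1)C(=O)C2` gives 90 nM. The two measured steps, a 3.9-fold lower number from compound 1 to compound 2 (0.59 log units; beyond the scatter) and a 4.8-fold lower number from compound 1 to compound 3 (0.68 log units; beyond the scatter), are modest and both move away from compound 1 by replacing the whole 3-fluorophenyl group. Compound 4 `CC1(C)[C@H]2CC[C@]1(C)N(Cc1cn(-c3cccc(Br)c3)nn1)C(=O)C2` differs from compound 1 only by bromo in place of fluoro on an aromatic carbon. Within the data shown here, no measured step exchanges one halogen for another at the same place, so nothing here speaks directly to this change. The step from compound 1 to compound 4 is therefore expected to stay within the scatter, a 1.2-fold lower number from compound 1 to compound 4 (0.09 log units; within the scatter). Compound 4 is estimated at 350 nM, within 150 nM to 900 nM.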

Compound 4, half-maximal inhibitory concentration: 30 nM
Beside the measured number, compound 4's estimate is 12-fold (1.07 log units) above it; the measured number lies below the stated range.
By their numbers in this assay, from the lowest: compound 4; then compounds 3 and 2 (each within the scatter of the next); then compound 1.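

In this assay, within the data shown here, the halogen at this place, on an aromatic carbon meta to a large group, matters: bromo in place of fluoro gives a 14-fold lower number from compound 1 to compound 4 (1.16 log units; beyond the scatter), the only step printed as large. The 3-bromophenyl group also gives lower numbers than both earlier replacements of 3-fluorophenyl, with a 3.0-fold lower number from compound 3 to compound 4 (0.48 log units; beyond the scatter) and a 3.7-fold lower number from compound 2 to compound 4 (0.56 log units; beyond the scatter). No supporting data bear on why this single halogen exchange has so large an effect.

On these data alone, whether chloro or iodo at the same place would fit the same trend remains open. So does the effect of an amine or a methoxy group there.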